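Hydroxy-methylethyl for fluoromethyl on the chain: cytotoxicity expectation

The source may report more compounds than this note shows. Statements on the series, on what has been measured and on what is new or still open speak of the compounds shown alone.

Compound 3 `O=c1n(Cc2cc3cc(Cl)ccc3n2CCCCF)c2cnccc2n1C1CC1` stands at the limit of an ADME assay on HeLa cells (Homo sapiens) for cytotoxicity, read by ATP content, with a stated time of 3 days; on this read-out lower numbers stand for higher toxicity in this test and higher numbers for lower toxicity in this test: in this assay compound 3 gives > 50000 nM, a limit and not a number. Compound 1 `CS(=O)(=O)CCCn1c(Cn2c(=O)n(C3CC3)c3ccncc32)cc2cc(Cl)ccc21` likewise gives in this assay > 50000 nM, a limit. Compound 2 `O=C(O)CCCn1c(Cn2c(=O)n(C3CC3)c3ccncc32)cc2cc(Cl)ccc21` gives in this assay > 50000 nM, again a limit. The steps a step that the two limits leave unreadable from compound 1 to compound 2, a step that the two limits leave unreadable from compound 1 to compound 3 and a step that the two limits leave unreadable from compound 2 to compound 3 stay unreadable because of the limit of > 50000 nM in this assay, at which 3 of the 3 values shown sit.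

Compound 4 `CC(C)(O)CCCn1c(Cn2c(=O)n(C3CC3)c3ccncc32)cc2cc(Cl)ccc21` differs from compound 3 by 1-hydroxy-1-methylethyl in place of fluoromethyl on a saturated chain carbon, three bonds along the chain from an aromatic nitrogen. Among the compounds with values here, no measured step bears readably on this change, and the three chain ends already seen all sit at the limit, so no step beyond the scatter is expected in this assay. The expected step is a number no higher from compound 3 to compound 4 (the limit leaves the size open). Compound 4 is expected to give 50000 nM in this assay, with a range from 20000 nM to 120000 nM.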

Compound 4, half-maximal cytotoxic concentration: > 50000 nM
Compound 4: only a limit was reported; the forecaster's own chance of this, stated with the estimate: 80%; the middle value sits exactly at the limit.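

In this assay compound 4 gives > 50000 nM, a limit, and its steps to compound 1, compound 2 and compound 3 cannot be read: the limit of > 50000 nM in this assay, at which 4 of the 4 values shown sit. The compounds shown leave open whether these chain ends differ at all in this assay.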